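The compounds below may be only part of what the source reports. "The series", "measured", "known", "first", "only" and "open" are said of these compounds alone.

In a functional assay on SR cells (Homo sapiens) for inhibition, read by sulforhodamine B assay, with a stated time of 48 h (a higher number here means a weaker inhibitor of growth, a lower number a stronger inhibitor of growth), compound 1 `COc1ccc(-c2cc(/C=C/C(=O)c3ccc(N)cc3)[nH]n2)cc1` gives 6090 nM, and compound 2 `COc1cc(-c2cc(/C=C/C(=O)c3ccc(N)cc3)[nH]n2)cc(OC)c1OC` gives 2750 nM. Compound 2 holds the lowest number of the two, and its gap to compound 1 lies beyond the usual scatter. Compound 3 `COc1ccc(-c2cc(/C=C/C(=O)c3ccc(N)cc3)[nH]n2)cc1OC` has not been measured in this assay. Compound 3 differs from compound 2 by hydrogen in place of methoxy on an aromatic carbon. Because compound 1 with a single methoxy gives 6090 nM, a small rise is expected, a 1.5-fold higher number from compound 2 to compound 3 (0.16 log units; within the scatter), not beyond the scatter. Compound 3 is therefore estimated at 4000 nM, with a range from 1800 nM to 9000 nM.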

Compound 3, concentration for total growth inhibition: 5310 nM
Compound 3: middle estimate off by 1.3-fold (0.12 log units), on the low side; low and high end bracket the measured number.
By their numbers in this assay, from the lowest: compounds 2, 3 and 1 (each within the scatter of the next, the first and the last beyond it).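

In this assay, taking away the methoxy ortho to a methoxy group gives a 1.9-fold higher number from compound 2 to compound 3 (0.29 log units; within the scatter), and putting a methoxy on the ring of compound 1 gives a 1.1-fold lower number from compound 1 to compound 3 (0.06 log units; within the scatter). Each single methoxy change thus stays within the scatter, although the two compounds at the ends of this series, which differ in two places, lie beyond it. Nothing at hand accounts for these numbers. Going by these compounds, whether an amine, a hydroxy group or a chlorine atom on this aromatic carbon would move the number beyond the scatter remains open. So does the effect of a longer alkoxy chain there.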